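From carboxy to methoxycarbonyl on compound 3

The source may report more compounds than this note shows. Statements on the series, on what has been measured and on what is new or still open speak of the compounds shown alone.

In a functional assay on FM3A cells (Mus musculus) for cytotoxicity (on this read-out lower numbers stand for an effect already at smaller amounts and higher numbers for an effect only at larger amounts of compound), three compounds sharing one core have been measured. Compound 1 `COOC1(OOCCCCCCI)CCCCCCCCCCC1` gives 86000 nM, compound 2 `COOC1(OOCCCCCC(=O)O)CCCCCCCCCCC1` gives 14000 nM, and compound 3 `COOC1(OOCCC(=O)O)CCCCCCCCCCC1` gives 450 nM, the lowest number of the three. Compound 4 `COOC1(OOCCC(=O)OC)CCCCCCCCCCC1` differs from compound 3 by a single change, (methyl in place of hydrogen on an oxygen next to a carbonyl group), which turns carboxy to methoxycarbonyl. Within the data shown here, no measured step makes this same change, so the evidence is only indirect. Changes along the chain have moved the numbers in this assay: a 6.1-fold lower number from compound 1 to compound 2 (0.79 log units; beyond the scatter) was modest, while a 31-fold lower number from compound 2 to compound 3 (1.49 log units; beyond the scatter) and a 190-fold lower number from compound 1 to compound 3 (2.28 log units; beyond the scatter) were large. Among the measured compounds shown here, compound 3 already holds the lowest number, and compound 1, the only measured compound without a carboxy group, gives 86000 nM. Compound 2 keeps its carboxy group and still gives 14000 nM, so the group alone does not settle the matter. A moderate rise is expected, with an estimated 3.3-fold higher number from compound 3 to compound 4 (0.52 log units; beyond the scatter). For compound 4 the expected value is 1500 nM, with an estimated range from 250 nM to 10000 nM.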

Compound 4, half-maximal effective concentration: 1400 nM
The estimate for compound 4 lay 1.1-fold (0.03 log units) above the measured number, within the range that was stated.
By their numbers in this assay, from the lowest: compound 3; then compound 4; then compound 2; then compound 1.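

In this assay, methyl in place of hydrogen on an oxygen next to a carbonyl group gives a 3.1-fold higher number from compound 3 to compound 4 (0.49 log units; beyond the scatter), so this position now has a direct measured step, and that step is modest. A free carboxy group is thus not needed to stay clear of the two highest numbers, with a 10-fold lower number from compound 2 to compound 4 (1.00 log units; beyond the scatter) and a 61-fold lower number from compound 1 to compound 4 (1.79 log units; beyond the scatter). Nothing available explains the size of the step at this oxygen.

The compounds shown leave open whether an ethyl ester, a primary amide or a primary alcohol in place of methoxycarbonyl would fall nearer the carboxylic acid or further from it. They also leave open whether methoxycarbonyl on a longer chain would show a step of similar size.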